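The compounds below may be only part of what the source reports. "The series", "measured", "known", "first", "only" and "open" are said of these compounds alone.

Measured compounds:
compound 1 `Cc1ccc(OCC(=O)N(Cc2cccs2)C2COC2)cc1` — 23000 nM
compound 2 `CCN(Cc1cn[nH]c1)C(=O)COc1ccc(C)cc1` — "active" (no number reported)

Compound 1 carries the only number shown in an assay on HEK293 cells for agonist activity at transient receptor potential cation channel subfamily M member 8 (Homo sapiens), read by fluorescence and calcium flux, with a stated time of 15 min; on this read-out lower numbers stand for an effect already at smaller amounts and higher numbers for an effect only at larger amounts of compound; compound 2 has one further entry without a single number. Compound 3 `CON(Cc1cccs1)C(=O)COc1ccc(C)cc1` keeps the core of compound 1 and changes one place: methoxy in place of oxetan-3-yl on an amide-type nitrogen. No step between measured compounds is shown, so the size of this change has no precedent here. Compound 3 is expected to stay close to its parent, with the step of a 1.2-fold lower number from compound 1 to compound 3 (0.06 log units; within the scatter) not beyond the scatter in either direction, because compound 1 already gives 23000 nM, a weak value. Compound 3 is estimated at 20000 nM, within 5000 nM to 80000 nM.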

Compound 3, half-maximal effective concentration: 10 nM
For compound 3 the middle estimate is 2000-fold (3.30 log units) above the measured one; measured number outside the range, below it.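

In this assay, the group on the amide-type nitrogen proves decisive for the core of compound 1: methoxy in place of oxetan-3-yl brings a 2300-fold lower number from compound 1 to compound 3 (3.36 log units; beyond the scatter) in a single change. Both groups carry the same count of hydrogen-bond donors and acceptors, yet the step is large. Nothing at hand bears on the cause of this step.

The compounds shown leave open whether the oxygen of the methoxy group matters on this nitrogen. A plain ethyl group, a hydroxy group or a longer alkoxy chain in the same place would bear on that question.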